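A carboxyethyl chain in place of a sulfur group

The source may report more compounds than this note shows. Statements on the series, on what has been measured and on what is new or still open speak of the compounds shown alone.

Measured so far:
compound 1, `CC(C)(C)c1ccc(C(=O)NCc2ccc(NC(=O)C(F)(F)F)cc2Cl)cc1`: 14 nM
compound 2, `C[S+]([O-])c1ccc(CNC(=O)c2ccc(C(C)(C)C)cc2)cc1`: 1300 nM

In an assay on HeLa cells with Bile acid receptor (Homo sapiens) as the target, read by a luciferase reporter, with a stated time of 24 h (a higher number here means that more compound is needed for the effect, a lower number that less compound is needed), compound 2 gives 1300 nM, the higher of the two numbers. Compound 1, with 14 nM, sits well below it, and the gap between the two lies beyond the scatter. Among the compounds with values here, no pair of compounds that differ in a single place has been measured, so these two values show only how far apart the two ends of the small set lie, not what any one change does.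

Compound 3, `CC(C)(C)c1ccc(C(=O)NCc2ccc(CCC(=O)O)cc2)cc1`, has not yet been measured. It differs from compound 2 in one place: a group of 5 heavy atoms (3 carbon, 2 oxygen; no ring) in place of a group of 3 heavy atoms (1 carbon, 1 oxygen, 1 sulfur; no ring), on an aromatic carbon. The group that leaves has no common name; the group that enters is a 2-carboxyethyl chain, sitting on an aromatic carbon of a six-membered aromatic ring of carbon only, para to a large group.

Within the data shown here, with no matched step to lean on, the expectation rests on the wide spread between compounds 1 and 2 and on the size of the change itself. A downward step of moderate size, beyond the scatter, is expected: a 3.3-fold lower number from compound 2 to compound 3 (0.51 log units; beyond the scatter). Compound 3 is therefore estimated at 400 nM in this assay, with a range from 80 nM to 2500 nM.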

Compound 3, half-maximal effective concentration: 350 nM
The estimate for compound 3 lay 1.1-fold (0.06 log units) above the measured number, within the range that was stated.
By their numbers in this assay, from the lowest: compound 1; then compound 3; then compound 2.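

Within the data shown here, the comparison gives this position, an aromatic carbon para to a large group, its first step in which only one place changes: with the 2-carboxyethyl chain in place of the sulfur-bearing group, this assay shows a 3.7-fold lower number from compound 2 to compound 3 (0.57 log units; beyond the scatter). The position therefore accepts a replacement with a different atom make-up and more heavy atoms, and the number falls rather than rises, which the pair of compound 1 and compound 2 could not show because those two differ in more than one place. Nothing measured here explains why the number moves in this direction.

As far as these compounds go, it remains open whether the step depends on the carboxylic acid at the end of the chain or on the length of the chain, which a methyl ester, a primary amide, a carboxymethyl group or a longer carboxypropyl chain at the same position would help to separate. From the compounds shown here alone, it also remains open how the 2-carboxyethyl chain would behave in a compound that carries a chlorine on the same ring, as compound 1 does.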